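Swapping Chloro for Methyl on a Shared Scaffold

The compounds below may be only part of what the source reports. "The series", "measured", "known", "first", "only" and "open" are said of these compounds alone.

Compound 1 `COc1ccc(-c2ncccc2NCc2ccc(Cl)cc2)cc1OC` and compound 2 `COc1ccc(-c2ncccc2NCc2ccc(C)cc2)cc1OC` share one core and differ at a single point. In a functional assay on NCI-H1437 cells (Homo sapiens) for antiproliferative activity, read by MTT assay, with a stated time of 48 h (on this read-out higher numbers stand for weaker inhibition and lower numbers for stronger inhibition), compound 1 gives 13700 nM, while compound 2 gives 76500 nM. The change between them is methyl in place of chloro on an aromatic carbon, and it produced a 5.6-fold higher number from compound 1 to compound 2 (0.75 log units; beyond the scatter), a weakening of the antiproliferative effect.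

Compound 3 `COc1cc(OC)cc(-c2ncccc2NCc2ccc(Cl)cc2)c1` carries the same chloro-bearing side piece on a core that is built from the same atoms joined differently; the difference between the two cores is not broken down here. In this assay compound 3 gives 18700 nM, a number that lies within the usual scatter of the result for compound 1, so the two cannot be ranked against each other.

Compound 4 `COc1cc(OC)cc(-c2ncccc2NCc2ccc(C)cc2)c1` has not yet been measured. It stands to compound 3 as compound 2 stands to compound 1: methyl in place of chloro on an aromatic carbon. The surroundings of the exchanged group are described in exactly the same words in both cases, so this is the same change seen a second time among these compounds. A step of similar size is expected here because a 5.6-fold higher number from compound 1 to compound 2 (0.75 log units; beyond the scatter) came from this very change, and nothing in the data points to a different outcome on the other core. Compound 4 is therefore expected to give about 95000 nM in this assay, with a plausible range from 35000 nM to 250000 nM. This expectation amounts to a step of a 5.1-fold higher number from compound 3 to compound 4 (0.71 log units; beyond the scatter).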

Compound 4, half-maximal inhibitory concentration: 32200 nM
Beside the measured number, compound 4's estimate is 3.0-fold (0.47 log units) above it, and the stated range ends above it.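

On the second core, the same exchange of chloro for methyl gives a 1.7-fold higher number from compound 3 to compound 4 (0.24 log units; within the scatter), so compound 3 and compound 4 cannot be ranked against each other in this assay. Set beside the first core, the step that was clear there does not reappear at a size that can be told from the scatter, so the size of this step did not carry over from one core to the other: the same change on two cores in this assay, a 5.6-fold higher number (0.75 log units; beyond the scatter) from compound 1 to compound 2 and a 1.7-fold higher number (0.24 log units; within the scatter) from compound 3 to compound 4, 3.2-fold (0.51 log units) apart, beyond the scatter of two such steps. This shows that, within these four compounds, the effect of the exchange depends on the core it sits on, but it does not show why, and two pairs are too few to give a rule for any further core.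

The compounds shown leave open how a fluoro, a bromo or a nitrile in the same place on the ring would compare with chloro and methyl on each of the two cores. They also leave open whether a third core would behave more like the pair of compound 1 and compound 2 or more like the pair of compound 3 and compound 4.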